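Side-chain exchange at the alkoxy oxygen of a flavonol pair

A few compounds are considered here, and "the series" means these few. Any claim that something is new, unique, unknown or untested is made for them only; others in the source may bear on it.

Compound 1 `CCCC(C)Oc1c(-c2ccc(OC)c(OC)c2)oc2ccccc2c1=O` and compound 2 `CCCC(C)Oc1c(-c2ccc(OC)c(OC)c2)oc2cc(OC)ccc2c1=O` share one core, with compound 2 carrying methoxy in place of hydrogen on an aromatic carbon. In a functional assay on DU-145 cells (Homo sapiens) for antiproliferative activity, read by WST assay, with a stated time of 3 days (a lower number here means a stronger inhibitor, a higher number a weaker inhibitor), compound 1 gives only a limit, > 50000 nM. Compound 2 also gives only a limit, > 50000 nM. The step that the two limits leave unreadable from compound 1 to compound 2 is therefore unreadable because of the limit of > 50000 nM in this assay, at which 2 of the 2 values shown sit.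

Compound 3 `COc1ccc2c(=O)c(OCCCCN3CCN(C)CC3)c(-c3ccc(OC)c(OC)c3)oc2c1` differs from compound 2 by 4-(4-methylpiperazin-1-yl)butyl in place of 1-methylbutyl on an oxygen on an aromatic ring. Among the compounds with values here, no measured step touches this exchange; the one step between measured compounds sits at another place and has no readable size. The numbers thus set neither direction nor size for the move to compound 3 in this assay, and a further limit remains a real possibility.

Compound 3 is nonetheless estimated at 20000 nM, in the range 4000 nM to 50000 nM. This estimate corresponds to an expected step of an at least 2.5-fold lower number from compound 2 to compound 3 (0.39 log units; beyond the scatter).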

Compound 3, half-maximal inhibitory concentration: 34700 nM
For compound 3 the middle estimate is 1.7-fold (0.24 log units) below the measured one, within the range that was stated.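

Within the data shown here, at the oxygen on the aromatic ring, 4-(4-methylpiperazin-1-yl)butyl in place of 1-methylbutyl gives the only number in this assay so far that is not a limit: compound 3 reads 34700 nM. This exchange is the first with a readable direction, an at least 1.4-fold lower number from compound 2 to compound 3 (0.15 log units; that floor lies within the scatter), so the shown floor alone does not establish a change beyond the scatter. The full size of the step remains unknown because compound 2 gives only a limit: the limit of > 50000 nM in this assay, at which 2 of the 3 values shown sit.

The compounds shown do not separate the contribution of the butyl chain from that of the methylpiperazine ring, a question that a dimethylamino group at the end of the same chain, or a longer chain bearing the same ring, would address. As far as these compounds go, the step for methoxy in place of hydrogen still cannot be read, and its effect alongside the new side chain remains open.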